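Phenylalkoxy variation on the shared core

The source may report more compounds than this note shows. Statements on the series, on what has been measured and on what is new or still open speak of the compounds shown alone.

Compound 1 `Cn1c(=O)[nH]c2ccc(OCCc3cccc(Cl)c3)cc21` carries a 3-chlorophenyl on a saturated chain carbon, two bonds along the chain from an oxygen on an aromatic ring; in an assay on cells for inhibition of Amine oxidase [flavin-containing] A (Homo sapiens), read by fluorescence, with stated times of 30 min and 15 min (on this read-out lower numbers stand for stronger inhibition and higher numbers for weaker inhibition), compound 1 gives "not determined" (no result reported), so no number fixes where it stands. Compound 2 `Cn1c(=O)[nH]c2ccc(OCc3ccc(Cl)cc3)cc21` gives only a limit, > 500000 nM, in this assay. Within the data shown here, that limit is the sole evidence here (the limit of > 500000 nM in this assay, at which 1 of the 2 values shown sits). Compound 3 `Cn1c(=O)[nH]c2ccc(OCCCc3ccccc3)cc21` differs from compound 1 by benzyl in place of 3-chlorophenyl on a saturated chain carbon, two bonds along the chain from an oxygen on an aromatic ring. Among the measured compounds shown here, no measured step exists, so the size or direction of the change in this assay cannot be set from data; weak inhibition is expected. Compound 3 is estimated at 100000 nM, with an expected range of 5000 nM to 500000 nM.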

Compound 3, half-maximal inhibitory concentration: > 500000 nM
Compound 3 gave a limit, no number; the forecaster's own chance of this, stated with the estimate: 50%; middle value at least 5.0-fold (0.69 log units) from the limit.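

No step can be read between compound 1 and compound 3 in this assay. Compound 3 gives only a limit, > 500000 nM. The compounds shown leave open whether any phenylalkoxy variation on the shared core gives a numerical inhibition value in this assay.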